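The compounds below may be only part of what the source reports. "The series", "measured", "known", "first", "only" and "open" are said of these compounds alone.

The three measured compounds and their results:
compound 1, `OC1CCN(c2ccc(-c3ccccc3Cl)nn2)CC1`, 38 mg/kg;
compound 2, `Cc1ccc(-c2ccc(N3CCC(O)CC3)nn2)c(Cl)c1`, 17 mg/kg;
compound 3, `O=[N+]([O-])c1ccccc1-c1ccc(N2CCC(O)CC2)nn1`, 81 mg/kg.

All of these numbers come from a functional assay on the whole organism with Mus musculus as the target; on this read-out higher numbers stand for an effect only at larger amounts of compound and lower numbers for an effect already at smaller amounts. Compound 1 holds the second highest of the three numbers. Its nearest neighbour is compound 3: a 2.1-fold higher number from compound 1 to compound 3 (0.33 log units; beyond the scatter). Its furthest is compound 2: a 2.2-fold lower number from compound 1 to compound 2 (0.35 log units; beyond the scatter). Both of these steps change the aromatic ring that carries the chloro group, and both are modest in size.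

Compound 4, `CNC(=O)OC1CCN(c2ccc(-c3ccccc3Cl)nn2)CC1`, is not yet measured in this assay. It differs from compound 1 in one place: methylcarbamoyl in place of hydrogen on an oxygen on a saturated carbon. Seen one bond further out, the hydroxy of compound 1 becomes (methylcarbamoyl)oxy.

Neither measured step touches this part of the molecule; both concern the aromatic ring. They bear on the change only in a general way, showing that a single alteration in this small series has moved the number by modest amounts in either direction. Nothing measured gives a direction for a change on the oxygen on the saturated carbon. The expected step is therefore small, within the scatter, a 1.2-fold higher number from compound 1 to compound 4 (0.07 log units; within the scatter). Compound 4 is estimated at 45 mg/kg, with a range from 15 mg/kg to 135 mg/kg.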

Compound 4, dose for half-maximal effect: 13 mg/kg
The estimate for compound 4 lay 3.5-fold (0.54 log units) above the measured number; the whole stated range lies above it.
By their numbers in this assay, from the lowest: compounds 4 and 2 (each within the scatter of the next); then compound 1; then compound 3.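

In this assay the oxygen on the saturated carbon proves to be a place where a change moves the number: putting methylcarbamoyl in place of hydrogen there gives a 2.9-fold lower number from compound 1 to compound 4 (0.47 log units; beyond the scatter) as a modest step of its own. Going by these compounds alone, the earlier steps all concerned the aromatic ring, so this is the first sign that the hydroxy of compound 1 can be replaced by (methylcarbamoyl)oxy with the effect in the whole animal still present and now seen at smaller doses. No measurement at hand says what lies behind this shift.

One group on this oxygen cannot show whether the lower number belongs to methylcarbamoyl in particular or would also appear with a plain acetyl group, a dimethylcarbamoyl group or a methyl ether. Going by these compounds, it also remains open whether the same change would give a step of similar size on the aromatic ring pattern of compound 2 or compound 3, and what an amine in place of the hydroxy would do to the number.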